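Two Limits and a New Aryl Group

This account rests on a few compounds, and the source may have more. Where it says the series, first, only, none or still open, it means among the compounds named here.

Measured in a functional assay on HeLa cells (Homo sapiens) for antiproliferative activity, read by MTT assay, with a stated time of 72 h; a lower number here means a stronger inhibitor of growth, a higher number a weaker inhibitor of growth:
- compound 1 `Cc1ccc(-n2nnc(C(=O)Nc3ccc(SC#N)cc3)c2C)cc1C`: > 100000 nM
- compound 2 `Cc1ccc(Cl)c(-n2nnc(C(=O)Nc3ccc(SC#N)cc3)c2C)c1`: > 100000 nM

Compound 2 gives no actual number, and its > 100000 nM is a limit of the assay. The same holds for the whole set so far: the limit of > 100000 nM in this assay, at which 2 of the 2 values shown sit.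

Compound 3 `COc1cccc(-n2nnc(C(=O)Nc3ccc(SC#N)cc3)c2C)c1` keeps the shared core of compound 2 and carries 3-methoxyphenyl in place of 2-chloro-5-methylphenyl on an aromatic nitrogen.

Within the data shown here, the only measured step at this place is a step that the two limits leave unreadable from compound 1 to compound 2, so it offers no size to carry over. In this assay, therefore, no step beyond the scatter can be firmly expected, and compound 3 may well also end up as a limit. The expected step is a number no higher from compound 2 to compound 3 (the limit leaves the size open), with no direction favoured. For compound 3 the estimated value is 100000 nM, with an expected range from 20000 nM to 200000 nM.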

Compound 3, concentration for 50% growth inhibition: > 100000 nM
Compound 3: only a limit was reported (the forecaster's own chance of this, stated with the estimate: 70%); the middle value sits exactly at the limit.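

Compound 3 gives > 100000 nM, a limit of the assay, so no step among compound 1, compound 2 and compound 3 can be read, and all three sit at one limit: the limit of > 100000 nM in this assay, at which 3 of the 3 values shown sit.

The compounds shown leave open how strongly any of these aryl groups inhibits growth in this assay.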